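Fluoro added to compound 3, with every reading at a limit

The compounds below may be only part of what the source reports. "The series", "measured", "known", "first", "only" and "open" are said of these compounds alone.

Of the compounds shown here, three have been read in a functional assay on ECV-304 cells (Homo sapiens) for cytotoxicity (a lower number here means a stronger inhibitor, a higher number a weaker inhibitor), so far. Compound 1 `Cc1ccc(S(=O)(=O)NN2C(=S)S/C(=C\c3ccc(Cl)c(Cl)c3)C2O)cc1` gives > 50000 nM as a limit of the assay and not a number. Compound 2 `COc1ccc(S(=O)(=O)NN2C(=S)S/C(=C\c3ccc(Cl)c(Cl)c3)C2O)cc1` gives > 50000 nM and this too is a limit. Compound 3 `O=C1/C(=C/c2ccccc2F)SC(=S)N1NS(=O)(=O)c1ccccc1` gives > 50000 nM as a limit as well, so its position is known only from that bound. The series as a whole stands at the limit of > 50000 nM in this assay, at which 3 of the 3 values shown sit, with no numerical reading yet.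

Compound 4 `O=C1/C(=C/c2ccc(F)cc2F)SC(=S)N1NS(=O)(=O)c1ccccc1` differs from compound 3 by one change fluoro in place of hydrogen on an aromatic carbon that reads as fluoro in place of hydrogen on an aromatic carbon, or 2-fluorophenyl to 2,4-difluorophenyl. Going by the values given here, the one measured step is a step that the two limits leave unreadable from compound 1 to compound 2 and it concerns methoxy in place of methyl, so it offers no size to carry over to this change. No shift beyond the scatter is therefore expected in this assay and no direction can be argued. The expected step is a step that the limit leaves unreadable from compound 3 to compound 4 and a further limit is the likeliest report. The estimate for compound 4 is 60000 nM with an expected range from 25000 nM to 150000 nM if a number is obtained.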

Compound 4, half-maximal inhibitory concentration: > 50000 nM
Compound 4: only a limit was reported (the forecaster's own chance of this, stated with the estimate: 85%); the middle value lies beyond the limit too.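

In this assay compound 4 gives > 50000 nM, a limit of the assay and not a number. Compound 3 also stands at a limit, so no step can be read between compound 3 and compound 4. The compounds shown leave open whether any change to the series gives a numerical reading, as all readings remain at one bound: the limit of > 50000 nM in this assay, at which 4 of the 4 values shown sit.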